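Taking one chloro off compound 2

The source may hold more compounds than are shown below. What is called first, only, known or untested is meant among the compounds shown, and "the series" means these compounds.

In an ADME assay on HeLa cells (Homo sapiens) for cytotoxicity, read by XTT assay (a lower number here means that less compound is tolerated, a higher number that more compound is tolerated), compound 1 (`c1ccc(CCCC2COc3ccccc3C2)cc1`) gives 200000 nM. Compound 2 (`Clc1cccc(CCCC2COc3ccc(Cl)cc3C2)c1`) gives 200000 nM, level with compound 1 within the scatter. Compound 3 (`Clc1cccc(CCCC2COc3ccccc3C2)c1`) differs from compound 2 by one change, hydrogen in place of chloro on an aromatic carbon. No measured step sizes this change directly, and the two measured values show no gap. No shift beyond the scatter is therefore expected in this assay, in either direction. The step of no change at the digits printed from compound 2 to compound 3 (within the scatter) is the expected one. For compound 3 the estimate is 200000 nM, with an expected range of 100000 nM to 350000 nM.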

Compound 3, half-maximal cytotoxic concentration: 100000 nM
Compound 3: middle estimate off by 2.0-fold (0.30 log units), on the high side, within the range that was stated.
By their numbers in this assay, from the lowest: compounds 3, 1 and 2 (each within the scatter of the next).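

In this assay, going by these compounds alone, hydrogen in place of chloro on an aromatic carbon of the fused system gives a 2.0-fold lower number from compound 2 to compound 3 (0.30 log units; within the scatter), the first measured step at this position. Chloro in place of hydrogen on an aromatic carbon gives a 2.0-fold lower number from compound 1 to compound 3 (0.30 log units; within the scatter), so neither single change moves the number beyond the scatter among these compounds. No supporting measurement bears on either step.

From the compounds shown here alone, whether an amine or a carboxylic acid at this position would move the number beyond the scatter stays open. The same holds for a longer chain on the shared core.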